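Pyridyl isomer swap across two thiocarbamate amine heads

This account rests on a few compounds, and the source may have more. Where it says the series, first, only, none or still open, it means among the compounds named here.

Measured so far in a functional assay on MGC-803 cells (Homo sapiens) for antiproliferative activity, read by CCK-8 assay, with a stated time of 72 h, tested at 8 uM; on this read-out lower numbers stand for a weaker effect and higher numbers for a stronger effect at the one concentration tested:
- compound 1, `Nc1ccccc1NC(=O)c1ccc(CSC(=S)N2CCN(Cc3ccncc3)CC2)cc1`: 79.3%
- compound 2, `Nc1ccccc1NC(=O)c1ccc(CSC(=S)N2CCN(Cc3cccnc3)CC2)cc1`: 64.6%
- compound 3, `CN(Cc1ccncc1)C(=S)SCc1ccc(C(=O)Nc2ccccc2N)cc1`: 83.2%

Compound 1 and compound 2 share one core and differ only in the pyridyl ring: pyridin-3-yl in place of pyridin-4-yl on a saturated chain carbon bound to an amine nitrogen in a ring. Among the measured compounds shown here, the step of a number 14.7 percentage points lower from compound 1 to compound 2 (beyond the scatter) is the only measured step in the set. Compound 3 carries a different amine head; the difference between its core and that of compound 1 is not broken down here. Compound 3 and compound 1 sit within the scatter of each other in this assay, so no order is drawn between them, while compound 3 stands beyond the scatter from compound 2.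

Compound 4, `CN(Cc1cccnc1)C(=S)SCc1ccc(C(=O)Nc2ccccc2N)cc1`, has not yet been measured. It relates to compound 3 as compound 2 relates to compound 1: pyridin-3-yl in place of pyridin-4-yl on a saturated chain carbon bound to an amide-type nitrogen. This is the same kind of change, not the same change, since the saturated chain carbon in compound 1 is bound to an amine nitrogen in a ring, whereas in compound 3 it is bound to an amide-type nitrogen.

The expectation for compound 4 rests on one precedent only, the step from compound 1 to compound 2 in this assay; the step from compound 3 to compound 4 is estimated as a number 15.2 percentage points lower from compound 3 to compound 4 (beyond the scatter), of a similar size and direction. For the measured compounds named here, on that basis compound 4 is expected to give about 68% in this assay, estimated between 55% and 80%, the width reflecting that the surroundings of the changed position differ from those in the single measured precedent.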

Compound 4, a percentage reported as inhibition, at one concentration (the size of the read-out at that concentration, not a potency): 85.5%
Beside the measured number, compound 4's estimate is 17.5 percentage points below it, and the stated range ends below it.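

In this assay, pyridin-3-yl in place of pyridin-4-yl does not carry over as a fixed step from one core to the other, and the two steps differ: the same change on two cores in this assay, a number 14.7 percentage points lower (beyond the scatter) from compound 1 to compound 2 and a number 2.3 percentage points higher (within the scatter) from compound 3 to compound 4, 17 percentage points apart, beyond the scatter of two such steps. On the core of compound 3, the change gives a number 2.3 percentage points higher from compound 3 to compound 4 (within the scatter), so the drop seen on the core of compound 1, a number 14.7 percentage points lower from compound 1 to compound 2 (beyond the scatter), does not recur there, and the effect of this change has to be read core by core in this series. This does not show why the two cores part, nor that the change is without effect on the core of compound 3 at other concentrations, since each core offers a single pair read at one concentration, and two cores give no rule for a third.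

The compounds shown leave open how pyridin-2-yl or a plain phenyl in the same place would behave on either core, and whether a longer chain between the pyridyl ring and the nitrogen would keep the values of the pairs. On these data alone, it also remains open which of the two patterns a further amine head, such as morpholine or a dimethylamino group, would follow.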